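Swapping the halogen on the thioether aryl group

A few compounds are considered here, and "the series" means these few. Any claim that something is new, unique, unknown or untested is made for them only; others in the source may bear on it.

Measured so far:
compound 1 `Cc1cc(C)cc(SCc2ccc(/C=C/C(=O)Nc3ccccc3N)cc2)c1` gives 47.3% in a functional assay on A549 cells (Homo sapiens) for inhibition, read by CCK-8 assay, with a stated time of 72 h, tested at 8 uM; a higher number here means more inhibition of growth at the concentration tested, a lower number less inhibition of growth;
compound 2 `Nc1ccccc1NC(=O)c1ccc(CSc2cccc(F)c2)cc1` gives 72.7% in this assay.

Compound 2 stands highest of the two numbers, and its gap to compound 1 lies beyond the scatter. Compound 3 `Nc1ccccc1NC(=O)c1ccc(CSc2ccc(Cl)cc2)cc1` has not yet been measured. The change is 4-chlorophenyl in place of 3-fluorophenyl on a sulfur. Going by the values given here, no pair of measured compounds shows this kind of change, so no size of step is known from the data. The step from compound 2 to compound 3 is expected to be small, a number 2.7 percentage points lower from compound 2 to compound 3 (within the scatter), likely within the scatter. Compound 3 is estimated to reach 70%, between 50% and 85%.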

Compound 3, percent growth inhibition at one concentration: 50.4%
Beside the measured number, compound 3's estimate is 19.6 percentage points above it, within the range that was stated.
By their numbers in this assay, from the lowest: compounds 1 and 3 (each within the scatter of the next); then compound 2.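

The aryl group on the sulfur matters in this assay: 4-chlorophenyl in place of 3-fluorophenyl gives a number 22.3 percentage points lower from compound 2 to compound 3 (beyond the scatter), even though both groups have the same count of heavy atoms. This swap changes both the halogen and its place on the ring, so the two changes cannot be told apart here. No measurement shown explains the step.

Going by these compounds, what remains open is how a plain phenyl or a methoxyphenyl group on the same sulfur would read in this assay.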